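Replacing 3-chlorophenyl with (2-chlorophenyl)carbonyl in compound 1

A few compounds are considered here, and "the series" means these few. Any claim that something is new, unique, unknown or untested is made for them only; others in the source may bear on it.

Measured in a functional assay on MDA-MB-231 cells (Homo sapiens) for antiproliferative activity, read by MTT assay, with a stated time of 24 h; a lower number here means a stronger inhibitor, a higher number a weaker inhibitor:
- Compound 1 `O=C(NNc1cccc(Cl)c1)c1ccc(NS(=O)(=O)c2cnc(O)nc2O)cc1`: 17400 nM
- Compound 2 `O=C(NNc1cccc(Cl)c1)c1ccccc1NS(=O)(=O)c1cnc(O)nc1O`: 11800 nM
- Compound 3 `O=C(NNc1ccccc1F)c1ccccc1NS(=O)(=O)c1cnc(O)nc1O`: > 20000 nM (a limit)

Compound 1 stands within the scatter of compound 2, and neither is separated from the other. Compound 3 gave only a limit. Compound 4 `O=C(NNC(=O)c1ccccc1Cl)c1ccc(NS(=O)(=O)c2cnc(O)nc2O)cc1` differs from compound 1 as follows: (2-chlorophenyl)carbonyl in place of 3-chlorophenyl on an amine nitrogen. Among the compounds with values here, the one measured step at this place is an at least 1.6-fold higher number from compound 2 to compound 3 (0.22 log units; that floor lies within the scatter), and its floor lies within the scatter. Within the data shown here, no measured step brings in a carbonyl here, so no change beyond the scatter is expected in this assay. The expected 1.2-fold lower number from compound 1 to compound 4 (0.06 log units; within the scatter) is an estimate only. For compound 4 the estimated value is 15000 nM, with an expected range of 7000 nM to 28000 nM.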

Compound 4, half-maximal inhibitory concentration: 13900 nM
The estimate for compound 4 lay 1.1-fold (0.03 log units) above the measured number, and the stated range covers the measured number.
By their numbers in this assay, from the lowest: compounds 2, 4 and 1 (each within the scatter of the next). At a limit, above all of these: compound 3.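

In this assay, a change at this place can now be given a size, which the earlier step, resting on a limit, did not allow: a 1.3-fold lower number from compound 1 to compound 4 (0.10 log units; within the scatter). Bringing in a carbonyl with (2-chlorophenyl)carbonyl in place of 3-chlorophenyl on the amine nitrogen therefore does not separate compound 4 from compound 1. Compound 3 remains a limit: the limit of > 20000 nM in this assay, at which 1 of the 4 values shown sits.

The compounds shown leave open whether a carboxylic acid, an amine or a longer chain at this place would give a change beyond the scatter. No readable step here does so.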